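Adding a Methyl to the Aromatic Nitrogen of Compound 2

A few compounds are considered here, and "the series" means these few. Any claim that something is new, unique, unknown or untested is made for them only; others in the source may bear on it.

Measured in a functional assay on HCT-8 cells (Homo sapiens) for antiproliferative activity, read by MTT assay, with a stated time of 48 h; a higher number here means a weaker inhibitor, a lower number a stronger inhibitor:
- Compound 1 `COc1ccc2c(/C=C/C(=O)c3cc(N)c(OC)c(OC)c3)c[nH]c2c1`: 368 nM
- Compound 2 `COc1ccc2c(/C=C/C(=O)c3cc(OC)c(OC)c([N+](=O)[O-])c3)c[nH]c2c1`: 982 nM
- Compound 3 `COc1cc(C(=O)/C=C/c2c[nH]c3ccccc23)cc([N+](=O)[O-])c1OC`: 1390 nM

Compound 2 gives 982 nM, and two measured steps fix its place among the three: a 1.4-fold higher number from compound 2 to compound 3 (0.15 log units; within the scatter), and a 2.7-fold higher number from compound 1 to compound 2 (0.43 log units; beyond the scatter). Compound 4 `COc1ccc2c(/C=C/C(=O)c3cc(OC)c(OC)c([N+](=O)[O-])c3)cn(C)c2c1` differs from it by methyl in place of hydrogen on an aromatic nitrogen. Neither measured step, nitro in place of amino or hydrogen in place of methoxy, involves that nitrogen. The data therefore give no direct size for this change, and no shift beyond the scatter is expected in this assay. The expected step is a 1.2-fold lower number from compound 2 to compound 4 (0.09 log units; within the scatter). Compound 4 is estimated at 800 nM, with an expected range of 250 nM to 2500 nM.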

Compound 4, half-maximal inhibitory concentration: 753 nM
Estimate against measurement, compound 4: 1.1-fold (0.03 log units) above; the measured number falls inside the stated range.
By their numbers in this assay, from the lowest: compound 1; then compounds 4, 2 and 3 (each within the scatter of the next).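

In this assay, for the compounds shown here, methyl in place of hydrogen on the aromatic nitrogen gives a 1.3-fold lower number from compound 2 to compound 4 (0.12 log units; within the scatter) and so adds the first measured step at this position. The nitrogen of compound 4 carries no hydrogen, yet its number stays within the scatter of that of compound 2. Nothing shown here accounts for this result.

The compounds shown leave open whether a longer chain, such as propyl, or a chain ending in an amine would be accommodated on this nitrogen. They also leave open whether methyl there would give a similar step in the amino-bearing compound 1.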